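This account rests on a few compounds, and the source may have more. Where it says the series, first, only, none or still open, it means among the compounds named here.

Of the compounds shown here, three built on one shared core have been tested in an assay on HEK293 cells for displacement of a labelled ligand from NPC1-like intracellular cholesterol transporter 1 (Homo sapiens); on this read-out lower numbers stand for stronger inhibition and higher numbers for weaker inhibition. Compound 1 `O=C(CN1CN(c2ccccc2)C2(CCN(C(=O)c3ccc(C4CCCCC4)cc3)CC2)C1=O)NCCCCO` gives 10300 nM. Compound 2 `CCOC(=O)C1CCN(C(=O)CN2CN(c3ccccc3)C3(CCN(C(=O)c4ccc(C5CCCCC5)cc4)CC3)C2=O)CC1` gives 900 nM, and compound 3 `O=C(CN1CN(c2ccccc2)C2(CCN(C(=O)c3ccc(C4CCCCC4)cc3)CC2)C1=O)NCCO` gives 2000 nM. Compound 2 therefore stands lowest of the three numbers: its nearest neighbour is compound 3, separated by the step of a 2.2-fold higher number from compound 2 to compound 3 (0.35 log units; beyond the scatter), and its furthest is compound 1, separated by the step of an 11-fold lower number from compound 1 to compound 2 (1.06 log units; beyond the scatter).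

Compound 4 `CC(C)(C)OC(=O)NC1CCN(C(=O)CN2CN(c3ccccc3)C3(CCN(C(=O)c4ccc(C5CCCCC5)cc4)CC3)C2=O)CC1` has not yet been measured. It differs from compound 2 in one place: (tert-butoxycarbonyl)amino in place of ethoxycarbonyl on a saturated ring carbon. The measured steps that touch the same part of the molecule are an 11-fold lower number from compound 1 to compound 2 (1.06 log units; beyond the scatter) and a 2.2-fold higher number from compound 2 to compound 3 (0.35 log units; beyond the scatter), both swaps of the whole group on the carbonyl carbon, and a 5.2-fold lower number from compound 1 to compound 3 (0.71 log units; beyond the scatter), a shortening of a chain on that side. For the measured compounds named here, none of them alters a group sitting on the saturated ring carbon itself, so they show only that numbers in this set move by large or modest amounts when this part is exchanged, without pointing to a direction for the present change. For compound 4 the expected value is 900 nM, within a range from 300 nM to 3000 nM. The expected step of no change at the digits printed from compound 2 to compound 4 (within the scatter) is estimated to stay within the scatter.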

Compound 4, half-maximal inhibitory concentration: 4800 nM
Estimate against measurement, compound 4: 5.3-fold (0.73 log units) below, and the stated range ends below it.
By their numbers in this assay, from the lowest: compound 2; then compound 3; then compound 4; then compound 1.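

In this assay, for the compounds shown here, this is the first change made on the saturated ring carbon itself, three ring bonds from the ring nitrogen, and exchanging ethoxycarbonyl for (tert-butoxycarbonyl)amino gives a 5.3-fold higher number from compound 2 to compound 4 (0.73 log units; beyond the scatter), so the group at this position matters and not only the whole group on the carbonyl carbon. The exchange alters several things at once: the group grows from 5 to 8 heavy atoms, gains a nitrogen attached to the ring carbon, and goes from 0 to 1 hydrogen-bond donor, while its 2 hydrogen-bond acceptors stay the same in number. No measurement here bears on why the number rises, so the reason stays unknown.

The compounds shown leave open whether the rise follows the larger heavy-atom count or the nitrogen with its hydrogen, as this single step changes both together. A tert-butyl ester on the same ring carbon would keep the bulkier ending without that nitrogen, while a free amine or a carboxylic acid there would show how far the number moves with a much smaller group.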